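From a phenylethylamino group to piperazine on one core

This account rests on a few compounds, and the source may have more. Where it says the series, first, only, none or still open, it means among the compounds named here.

Of the compounds shown here, three sharing one core have been tested in a functional assay on MDA-MB-435 cells (Homo sapiens) for cytotoxicity, read by MTT assay, with a stated time of 72 h; a higher number here means a weaker inhibitor, a lower number a stronger inhibitor. Compound 1 (`Nc1cccc(Nc2c(C(=O)NCc3ccc(F)cc3)nc(Br)c3cccnc23)c1`), with 3-aminophenyl on a nitrogen on an aromatic ring, gives 8000 nM. Compound 2 (`O=C(NCc1ccc(F)cc1)c1nc(Br)c2cccnc2c1NCc1ccc(F)cc1`), with 4-fluorobenzyl there, reaches only a limit, > 20000 nM. Compound 3 (`C[C@H](Nc1c(C(=O)NCc2ccc(F)cc2)nc(Br)c2cccnc12)c1ccccc1`), with 1-phenylethyl there, also reaches only a limit, > 20000 nM. Compound 3 therefore stands at the limit of > 20000 nM in this assay, at which 2 of the 3 values shown sit.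

Compound 4 (`O=C(NCc1ccc(F)cc1)c1nc(Br)c2cccnc2c1N1CCNCC1`) has not yet been measured. It carries piperazin-1-yl in place of the (1-phenylethyl)amino of compound 3, on an aromatic carbon para to a bromo group: piperazin-1-yl in place of (1-phenylethyl)amino on an aromatic carbon.

For the measured compounds named here, no measured step introduces piperazin-1-yl, so the evidence is indirect. Two steps change the same group: an at least 2.5-fold higher number from compound 1 to compound 2 (0.39 log units; beyond the scatter) and an at least 2.5-fold higher number from compound 1 to compound 3 (0.39 log units; beyond the scatter). Both lie beyond the scatter, though both are minimum sizes. The remaining step, a step that the two limits leave unreadable from compound 2 to compound 3, cannot be read. A modest move towards stronger inhibition is expected, because compound 1 gives 8000 nM and so shows that a measurable value is possible on this core. Another limit would be no surprise. The estimate means an at least 1.3-fold lower number from compound 3 to compound 4 (0.12 log units; that floor lies within the scatter), an expected step of uncertain size. For compound 4 the estimated value is 15000 nM, within an expected range from 5000 nM to 40000 nM.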

Compound 4, half-maximal inhibitory concentration: 8000 nM
Beside the measured number, compound 4's estimate is 1.9-fold (0.27 log units) above it; low and high end bracket the measured number.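

At this aromatic carbon para to a bromo group, the new compound shows that the measurable activity seen in this assay is not confined to the (3-aminophenyl)amino group: piperazin-1-yl in place of (1-phenylethyl)amino gives an at least 2.5-fold lower number from compound 3 to compound 4 (0.39 log units; beyond the scatter), and in place of (4-fluorobenzyl)amino it gives an at least 2.5-fold lower number from compound 2 to compound 4 (0.39 log units; beyond the scatter). Against the (3-aminophenyl)amino group there is no change at the digits printed from compound 1 to compound 4 (within the scatter), so a six-membered non-aromatic ring with 2 hetero atoms does as well here as a group carrying an aromatic ring of carbon only, and an aromatic ring in this group is not needed for a measured value. Nor is such a ring enough, since compound 2 and compound 3 both carry one and each stops at a limit: the limit of > 20000 nM in this assay, at which 2 of the 4 values shown sit.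

As far as these compounds go, the step from compound 2 to compound 3 cannot be read, and it stays unknown which of those two groups is the weaker. From the compounds shown here alone, it also stays open whether the piperazine's other nitrogen matters, a question that morpholin-4-yl, with an oxygen in its place, or 4-methylpiperazin-1-yl could address.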